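The source may hold more compounds than are shown below. What is called first, only, known or untested is meant among the compounds shown, and "the series" means these compounds.

Measured compounds:
compound 1 `Nc1ccccc1NC(=O)c1ccc(Cn2cnc3c(Nc4ccccc4)nc(Cl)nc32)cc1`, 71.4%
compound 2 `Nc1ccccc1NC(=O)c1ccc(Cn2cnc3c(NCc4ccccc4)nc(Cl)nc32)cc1`, 68.3%
compound 3 `Nc1ccccc1NC(=O)/C=C/c1ccc(Cn2cnc3c(Nc4ccccc4)nc(Cl)nc32)cc1`, 7.75%

In a functional assay on HCT-116 cells (Homo sapiens) for antiproliferative activity, read by CCK-8 assay, with a stated time of 72 h, tested at 2 uM (on this read-out lower numbers stand for a weaker effect and higher numbers for a stronger effect at the one concentration tested), compound 1 gives 71.4% and compound 2 gives 68.3%. The change between them is benzyl in place of phenyl on a nitrogen on an aromatic ring, and the step of a number 3.1 percentage points lower from compound 1 to compound 2 (within the scatter) is small. Compound 3 differs from compound 1 in the core: 2-((2-aminophenyl)carbamoyl)ethenyl in place of (2-aminophenyl)carbamoyl on an aromatic carbon, and the step of a number 63.7 percentage points lower from compound 1 to compound 3 (beyond the scatter) is large, leaving compound 3 at 7.75%.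

Compound 4 `Nc1ccccc1NC(=O)/C=C/c1ccc(Cn2cnc3c(NCc4ccccc4)nc(Cl)nc32)cc1` is not yet measured. It differs from compound 3 by benzyl in place of phenyl on a nitrogen on an aromatic ring, the same change as from compound 1 to compound 2, at a place described in the same words. Because a number 3.1 percentage points lower from compound 1 to compound 2 (within the scatter) stayed within the scatter, the step of a number 1.8 percentage points lower from compound 3 to compound 4 (within the scatter) is expected to be small as well, and compound 4 is estimated at 6% in this assay, with a range from 0% to 20%.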

Compound 4, a percentage reported as inhibition, at one concentration (the size of the read-out at that concentration, not a potency): 2.85%
For compound 4 the middle estimate is 3.2 percentage points above the measured one; the range from low to high includes it.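

In this assay, the step for benzyl in place of phenyl on the second core is a number 4.9 percentage points lower from compound 3 to compound 4 (within the scatter), and it matches the step on the first core: the same change on two cores in this assay, a number 3.1 percentage points lower (within the scatter) from compound 1 to compound 2 and a number 4.9 percentage points lower (within the scatter) from compound 3 to compound 4, 1.8 percentage points apart, within the scatter of two such steps. The step for the 2-((2-aminophenyl)carbamoyl)ethenyl change, read with benzyl present, is a number 65.5 percentage points lower from compound 2 to compound 4 (beyond the scatter), and it also matches its earlier counterpart: the same change on two cores in this assay, a number 63.7 percentage points lower (beyond the scatter) from compound 1 to compound 3 and a number 65.5 percentage points lower (beyond the scatter) from compound 2 to compound 4, 1.8 percentage points apart, within the scatter of two such steps. This shows that each change carried over between the two cores in these four compounds, but it does not show that this would hold on other cores, and the low values on the ethenyl side leave little room for any further fall.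

The compounds shown leave open how a longer chain, such as phenethyl, would behave on that nitrogen. They also leave open what an amine in place of the chlorine would do.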